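Aryl substituent variation on a shared core

The source may hold more compounds than are shown below. What is called first, only, known or untested is meant among the compounds shown, and "the series" means these compounds.

Measured so far:
- compound 1 `Cc1ccc(CN2CC=C(CCC(=O)NO)C2=O)cc1`: 4620 nM
- compound 2 `Cc1ccc(CCCCN2CC=C(CCC(=O)NO)C2=O)cc1`: 6090 nM
- compound 3 `O=C(CCC1=CCN(Cc2cccc(Cl)c2)C1=O)NO`: 4620 nM

All three numbers come from a functional assay on PC-3 cells (Homo sapiens) for inhibition, read by sulforhodamine B assay; on this read-out higher numbers stand for weaker inhibition of growth and lower numbers for stronger inhibition of growth. Compound 1 and compound 3 give the same number at the digits shown, together the lowest of the three; compound 2 gives a higher number, but the gap from compound 1 to compound 2 lies within the scatter, so the three compounds are not separated by this assay. Among the compounds with values here, no pair here differs in only one place, so no single-change step can be read from the measured set.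

Compound 4 `CC(C)(C)c1ccc(CN2CC=C(CCC(=O)NO)C2=O)cc1` is the next compound to be measured in this assay. It differs from compound 1 as follows: tert-butyl in place of methyl on an aromatic carbon.

Within the data shown here, with no comparable step among the measured compounds, the expectation rests on the narrow spread seen from compound 1 to compound 3 and to compound 2, which stays within the scatter. The step from compound 1 to compound 4 is expected to be small, a 1.1-fold higher number from compound 1 to compound 4 (0.03 log units; within the scatter), with no direction claimed beyond the scatter. Compound 4 is therefore estimated at 5000 nM in this assay, with a range from 2000 nM to 12000 nM.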

Compound 4, concentration for 50% growth inhibition: 1830 nM
The estimate for compound 4 lay 2.7-fold (0.44 log units) above the measured number, and the stated range ends above it.
By their numbers in this assay, from the lowest: compound 4; then compounds 1, 3 and 2 (each within the scatter of the next).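

At the aromatic carbon para to a large group, this assay shows a 2.5-fold lower number from compound 1 to compound 4 (0.40 log units; beyond the scatter) when tert-butyl replaces methyl. Within the data shown here, this is the first single-place step and it lies beyond the scatter, so this position is not indifferent to the group it carries, though the step is modest. The entering group adds carbon only, with no ring, hydrogen-bond donor, hydrogen-bond acceptor or net charge, and no measurement on hand accounts for the lower number.

One step between methyl and tert-butyl does not show whether the number follows the count of carbon atoms in the group or is particular to tert-butyl. Also open, on these data alone, is how this assay would read with an amine, a carboxylic acid or a longer linear alkyl chain on the same aromatic carbon.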